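Swapping the thiazole side chain for an acrylate ester

The compounds below may be only part of what the source reports. "The series", "measured", "known", "first", "only" and "open" are said of these compounds alone.

Compound 1: `COc1ccc(-c2nc(/N=C(\N)N(C)C)sc2-c2ccc(OC)cc2)cc1` — 4.8 uM
Compound 2: `CNC(=O)NCc1nc(-c2ccc(OC)cc2)c(-c2ccc(OC)cc2)s1` — 15 uM

Both compounds were tested in a functional assay (aorta) with Rattus norvegicus as the target; on this read-out higher numbers stand for an effect only at larger amounts of compound and lower numbers for an effect already at smaller amounts. Within the data shown here, compound 1 gives 4.8 uM there, and compound 2 gives 15 uM, so compound 2 stands as the higher of the two numbers, with compound 1 the only comparison and a 3.1-fold higher number from compound 1 to compound 2 (0.49 log units; beyond the scatter) separating them. That single measured step is the only one available, and it concerns the same position on the shared core that changes again here.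

Compound 3 is `CCOC(=O)/C=C/c1nc(-c2ccc(OC)cc2)c(-c2ccc(OC)cc2)s1`. It differs from compound 2 in one place: 2-(ethoxycarbonyl)ethenyl in place of ((methylcarbamoyl)amino)methyl on an aromatic carbon. Among the measured compounds shown here, the one known step at this position was modest, so a change of comparable size in this assay seems the most reasonable expectation, without a firm direction; with no donor left in the new group and nothing measured to anchor it, a slight drift toward a higher number is taken as the central guess. Compound 3 is therefore estimated at 20 uM, within a range of 6 uM to 70 uM, which corresponds to an expected step of a 1.3-fold higher number from compound 2 to compound 3 (0.12 log units; within the scatter).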

Compound 3, concentration for half-maximal effect: > 100 uM
Compound 3 ended at the assay's limit (the forecaster's own chance of this, stated with the estimate: 10%); at least 5.0-fold (0.69 log units) between middle value and limit.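

Compound 3 gives no number in this assay, only a limit of the assay: the limit of > 100 uM in this assay, at which 1 of the 3 values shown sits.

Where a 3.1-fold higher number from compound 1 to compound 2 (0.49 log units; beyond the scatter) was a modest change, the group on this aromatic carbon turns out to matter much more, with an at least 6.6-fold higher number from compound 2 to compound 3 (0.82 log units; beyond the scatter) and an at least 20-fold higher number from compound 1 to compound 3 (1.31 log units; beyond the scatter). Among these three compounds, the two with a measured number carry nitrogen in this group, while 2-(ethoxycarbonyl)ethenyl, which has no nitrogen and no hydrogen-bond donors, is the one that ends at the limit.

The compounds shown cannot tell which part of the change counts: the loss of nitrogen, the loss of the hydrogen-bond donors, the ester, or the double bond in the chain, and how far compound 3 lies past the limit also stays unknown. A carboxylic acid or an amide in place of the ester on the same chain, or a simple amine on a short chain at this position, would help to separate these possibilities.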